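This account rests on a few compounds, and the source may have more. Where it says the series, first, only, none or still open, it means among the compounds named here.

In a functional assay on DU-145 cells (Homo sapiens) for cytotoxicity, read by MTT assay, with a stated time of 24 h (on this read-out lower numbers stand for stronger inhibition and higher numbers for weaker inhibition), compound 1 `O=C1/C(=C/c2ccccc2F)CN(Cc2cn(Cc3ccccc3F)nn2)C/C1=C\c1ccccc1F` gives 10600 nM, compound 3 `O=C1/C(=C/c2ccccc2F)CN(Cc2cn(Cc3cccc(Cl)c3)nn2)C/C1=C\c1ccccc1F` gives 4300 nM, and compound 2 `COc1ccc(/C=C2\CN(C(=S)SCc3cn(Cc4ccc(F)cc4)nn3)C/C(=C\c3ccc(OC)cc3)C2=O)cc1` gives 74600 nM, the highest of the three numbers. Compound 4 `COc1ccc(/C=C2\CN(C(=S)SCc3cn(Cc4ccccc4Cl)nn3)C/C(=C\c3ccc(OC)cc3)C2=O)cc1` has not yet been measured. It differs from compound 2 in one place: 2-chlorophenyl in place of 4-fluorophenyl on a saturated chain carbon bound to an aromatic nitrogen. In words, this is 2-chlorophenyl in place of 4-fluorophenyl on a saturated chain carbon bound to an aromatic nitrogen, or 4-fluorobenzyl to 2-chlorobenzyl.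

Within the data shown here, only one measured step bears on this change, and it does so indirectly. That step is a 2.5-fold lower number from compound 1 to compound 3 (0.39 log units; beyond the scatter), a modest change in which 3-chlorophenyl replaces 2-fluorophenyl on a saturated chain carbon bound to an aromatic nitrogen. Among the measured compounds shown here, it too brings in a chlorine-bearing ring for a fluorine-bearing one, but the substitution positions differ, and the rest of the molecule is not the one shared by compound 2 and compound 4. For the measured compounds named here, no measured compound carries the 2-chlorophenyl group. A modest move to a lower number is therefore expected, with wide uncertainty, and it could still fall within the scatter. The expected change is a 2.1-fold lower number from compound 2 to compound 4 (0.33 log units; beyond the scatter). For compound 4 the estimated value is 35000 nM, with an expected range from 12000 nM to 90000 nM.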

Compound 4, half-maximal inhibitory concentration: > 80000 nM
Compound 4: only a limit was reported (the forecaster's own chance of this, stated with the estimate: 5%); middle value at least 2.2-fold (0.35 log units) away from the limit.
By their numbers in this assay, from the lowest: compound 3; then compound 1; then compound 2. At a limit, above all of these: compound 4.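

In this assay compound 4 gives > 80000 nM, which is a limit of the assay and not a number. Among these compounds, on the core shared by these two compounds, 2-chlorophenyl in place of 4-fluorophenyl gives an at least 1.0-fold higher number from compound 2 to compound 4 (0.03 log units; that floor lies within the scatter), so the move to a lower number seen in the only earlier step with a chlorine-bearing ring, a 2.5-fold lower number from compound 1 to compound 3 (0.39 log units; beyond the scatter), on a different core, does not carry over to this change. Only the floor of the new step is known and it lies within the scatter, so the result gives a direction that may be no real change, and the true size of the step cannot be read: the limit of > 80000 nM in this assay, at which 1 of the 4 values shown sits.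

The compounds shown leave open how much of this outcome belongs to the swap of fluorine for chlorine and how much to where the halogen sits on the ring, a question that 4-chlorophenyl at this place on the core of compound 2 would address. As far as these compounds go, it is also open whether 2-chlorophenyl would behave the same way on the core of compound 1, and whether a ring carrying an amine or a carboxylic acid at this place would give a measurable number.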